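This account rests on a few compounds, and the source may have more. Where it says the series, first, only, none or still open, it means among the compounds named here.

Measured in a physicochemical assay for lipophilicity, read by HPLC, at pH 7.5; on this read-out higher numbers stand for higher lipophilicity and lower numbers for lower lipophilicity:
- compound 1 `CC[C@@H](Nc1c(C#N)c(-c2ccc(-c3ccc(F)cc3)cc2)nc2cnccc12)C(N)=O`: 2.7
- compound 2 `CC[C@@H](Nc1c(C#N)c(-c2ccc(-c3ccccc3COC)cc2)nc2cnccc12)C(N)=O`: 2.6
- compound 3 `CCOc1ccccc1-c1ccc(-c2nc3cnccc3c(N[C@H](CC)C(N)=O)c2C#N)cc1`: 3

Compound 3 gives 3. Comparing it with the other two shows a number 0.30 log units higher from compound 1 to compound 3 (within the scatter) and a number 0.40 log units higher from compound 2 to compound 3 (beyond the scatter). It therefore cannot be told apart from compound 1, but it stands clear of compound 2.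

The next compound to consider is compound 4 `CC[C@@H](Nc1c(C#N)c(-c2ccc(-c3ccccc3C(F)(F)F)cc2)nc2cnccc12)C(N)=O`, which has not yet been measured. It carries trifluoromethyl in place of ethoxy on an aromatic carbon, ortho to a large group: trifluoromethyl in place of ethoxy on an aromatic carbon.

Going by the values given here, no measured step brings in trifluoromethyl, so the evidence is indirect. The closest guide is the change at the same place, a number 0.40 log units higher from compound 2 to compound 3 (beyond the scatter), and the other swaps of this group gave a number 0.10 log units lower from compound 1 to compound 2 (within the scatter) and a number 0.30 log units higher from compound 1 to compound 3 (within the scatter). All of these are small, so a small step seems the fair expectation here as well. The expected step is a number 0.10 log units higher from compound 3 to compound 4 (within the scatter), which would not stand out from the scatter. The estimated value for compound 4 is 3.1, with an expected range from 2.7 to 3.5.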

Compound 4, distribution coefficient: 3.1
Compound 4: middle estimate and measured number agree at the digits printed, and the stated range covers the measured number.
By their numbers in this assay, from the lowest: compounds 2, 1, 3 and 4 (each within the scatter of the next, the first and the last beyond it).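

In this assay, trifluoromethyl in place of ethoxy gives a number 0.10 log units higher from compound 3 to compound 4 (within the scatter) and so does not separate the two groups, even though the hydrogen-bond acceptor count of the group falls from one to none. Compound 4 does stand apart from the other two compounds, with a number 0.50 log units higher from compound 2 to compound 4 (beyond the scatter) and a number 0.40 log units higher from compound 1 to compound 4 (beyond the scatter) as its steps, whereas compound 3 could not be told apart from compound 1 on this read-out. Nothing measured here gives a reason for any of these steps. The compounds shown leave open how an amine or a carboxylic acid on this same aromatic carbon would read. They also leave open whether a longer chain than ethoxy, such as butoxy, would stay within the narrow spread seen so far.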